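This account rests on a few compounds, and the source may have more. Where it says the series, first, only, none or still open, it means among the compounds named here.

Compound 3 `CSc1nonc1/C(=N/O)Nc1ccc(F)c(Br)c1` has the highest number among the three measured compounds: in an assay for inhibition of Indoleamine 2,3-dioxygenase 1 (Homo sapiens), read by fluorescence, with a stated time of 24 h (a higher number here means a weaker inhibitor, a lower number a stronger inhibitor), compound 3 gives 15 nM. Compound 2 `CS(=N)(=O)CC(=O)NCCSc1nonc1/C(=N/O)Nc1ccc(F)c(Br)c1` sits within the usual scatter of it, since in this assay compound 2 gives 14 nM and a 1.1-fold higher number from compound 2 to compound 3 (0.03 log units; within the scatter). Compound 1 `NS(=O)(=O)NCCSc1nonc1/C(=N/O)Nc1ccc(F)c(Br)c1` stands clearly apart, because in this assay compound 1 gives 2.8 nM. Compound 4 `CS(=O)(=O)NCCSc1nonc1/C(=N/O)Nc1ccc(F)c(Br)c1` differs from compound 3 by (methanesulfonamido)methyl in place of hydrogen on a saturated chain carbon bound to a sulfur. Among the measured compounds shown here, two measured steps bear on this. The closest in kind is the one where a 5.4-fold higher number from compound 1 to compound 3 (0.73 log units; beyond the scatter), a group of similar shape and size at the same place. The other, where a 1.1-fold higher number from compound 2 to compound 3 (0.03 log units; within the scatter), shows that a group at this place can also leave the number essentially unchanged. The group entering in compound 4 resembles that of compound 1 more than that of compound 2, so the expected step is a 3.0-fold lower number from compound 3 to compound 4 (0.48 log units; beyond the scatter), a lower number, not quite reversing the earlier step. Compound 4 is therefore estimated at 5 nM, with a range from 2 nM to 15 nM.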

Compound 4, half-maximal inhibitory concentration: 9.3 nM
The estimate for compound 4 lay 1.9-fold (0.27 log units) below the measured number; low and high end bracket the measured number.
By their numbers in this assay, from the lowest: compound 1; then compounds 4, 2 and 3 (each within the scatter of the next).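

In this assay, (methanesulfonamido)methyl in place of hydrogen on a saturated chain carbon bound to a sulfur gives a 1.6-fold lower number from compound 3 to compound 4 (0.21 log units; within the scatter), so adding this group does not reproduce the clear step seen with compound 1. Exchanging the group on the amine nitrogen gives a 1.5-fold lower number from compound 2 to compound 4 (0.18 log units; within the scatter), so these two different groups read alike at this place. Among the compounds shown here, the one change that matters here is methyl in place of amino on a sulfonyl sulfur, which gives a 3.3-fold higher number from compound 1 to compound 4 (0.52 log units; beyond the scatter), showing that the low number of compound 1 depends on that amino group and not on the sulfonyl group alone.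

Nothing available here explains this difference. From the compounds shown here alone, whether a methylamino group on the sulfonyl sulfur would keep the low number of compound 1, and how a longer chain would read, stays open.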